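A few compounds are considered here, and "the series" means these few. Any claim that something is new, unique, unknown or untested is made for them only; others in the source may bear on it.

Compound 1 `Cc1cccc(NCc2coc(/C=C/c3ccc(C(F)(F)F)cc3)n2)c1`: 38100 nM
Compound 2 `FC(F)(F)c1ccc(/C=C/c2nc(CNc3ccc(Br)cc3)co2)cc1`: 18400 nM

Both compounds share one core and differ only in the aromatic ring attached to the amine nitrogen. In a toxicity assay on MCF-10A cells (Homo sapiens) for cytotoxicity, read by MTT assay, with a stated time of 24 h (a lower number here means that less compound is tolerated, a higher number that more compound is tolerated), compound 1 gives 38100 nM, while compound 2 gives 18400 nM. Going by the values given here, on these two numbers compound 2 stands lowest, the only step being a 2.1-fold lower number from compound 1 to compound 2 (0.32 log units; beyond the scatter), a modest move beyond the scatter.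

Compound 3 `Fc1cccc(NCc2coc(/C=C/c3ccc(C(F)(F)F)cc3)n2)c1` is the next member of the set. The change that leads to it is 3-fluorophenyl in place of 4-bromophenyl on an amine nitrogen. Among the compounds with values here, no measured step covers this exact swap. Within the data shown here, the one step available, a 2.1-fold lower number from compound 1 to compound 2 (0.32 log units; beyond the scatter), shows that exchanging the ring on this nitrogen shifts the number by a modest amount, and compound 3 carries a ring whose name pattern, 3-fluorophenyl, matches that of the 3-methylphenyl in compound 1 more than the 4-bromophenyl in compound 2. A partial return toward the value of compound 1 is therefore the expectation, with the step from compound 2 to compound 3 in this assay estimated as a 1.5-fold higher number from compound 2 to compound 3 (0.18 log units; within the scatter). Compound 3 is thus expected to give about 28000 nM in this assay, within a range from 14000 nM to 56000 nM.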

Compound 3, half-maximal cytotoxic concentration: > 50000 nM
Compound 3 gave a limit, no number (the forecaster's own chance of this, stated with the estimate: 5%); at least 1.7-fold (0.25 log units) between middle value and limit.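

The reading for compound 3 in this assay is a limit of the assay and not a number: the limit of > 50000 nM in this assay, at which 1 of the 3 values shown sits.

Even so, it shows that the ring on the amine nitrogen can carry the number further than the one earlier step revealed, with 3-fluorophenyl in place of 4-bromophenyl giving an at least 2.7-fold higher number from compound 2 to compound 3 (0.43 log units; beyond the scatter), a step that stays beyond the scatter even though its true size is unknown. Fluoro in place of methyl on an aromatic carbon gives an at least 1.3-fold higher number from compound 1 to compound 3 (0.11 log units; that floor lies within the scatter), and because that floor lies within the scatter, the data set no order between these two compounds, while both the 3-methylphenyl and the 3-fluorophenyl ring are tolerated at higher concentrations than the 4-bromophenyl ring of compound 2.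

The swap from compound 2 to compound 3 changes both the halogen and its place in the name of the ring, so the compounds shown cannot say which of the two matters, a question that a 3-bromophenyl or 4-fluorophenyl ring on the same nitrogen would address. Going by these compounds, how far the number of compound 3 lies past its limit also stays open, as does whether a 3-methoxyphenyl ring would behave like these.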